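A few compounds are considered here, and "the series" means these few. Any claim that something is new, unique, unknown or untested is made for them only; others in the source may bear on it.

Measured so far in a functional assay on MDA-MB-231 cells (Homo sapiens) for inhibition, read by MTT assay, with a stated time of 72 h; a lower number here means a stronger inhibitor, a higher number a weaker inhibitor:
Compound 1, `Nc1ncnc2c1c(-c1cnc3[nH]ccc3c1)nn2CCCCCCCCC(=O)NO`, gives 11000 nM.
Compound 2, `Nc1ncnc2c1c(-c1cnc3[nH]ccc3c1)nn2CCCCCCCCCC(=O)NO`, gives 10100 nM.
Compound 3, `Nc1nc2cc(-c3nn(CCCCC(=O)NO)c4ncnc(N)c34)ccc2o1`, gives 21200 nM.

Compounds 1 and 2 share one core, and compound 3 carries another; the difference between the two cores is not broken down here. Compound 1 and compound 2 differ in a single place: (hydroxycarbamoyl)methyl in place of hydroxycarbamoyl on a saturated chain carbon, eight bonds along the chain from an aromatic nitrogen. That change gave a 1.1-fold lower number from compound 1 to compound 2 (0.04 log units; within the scatter), so adding one link to the chain at that point left the result essentially where it was. Compound 3 gives a higher number than compound 2, while its number and that of compound 1 lie within the scatter of each other, so no order between those two can be read.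

Compound 4, `Nc1nc2cc(-c3nn(CCCCCC(=O)NO)c4ncnc(N)c34)ccc2o1`, has not yet been measured. It comes from compound 3 by (hydroxycarbamoyl)methyl in place of hydroxycarbamoyl on a saturated chain carbon, four bonds along the chain from an aromatic nitrogen. Among the compounds with values here, this is the same kind of change as the one from compound 1 to compound 2, but the place differs: in compound 1 it sits eight bonds along the chain from an aromatic nitrogen, in compound 3 four bonds along the chain from an aromatic nitrogen. Within the data shown here, only one earlier example exists, on a different core and a longer chain, so the expectation rests on that example alone. Because the earlier step was a 1.1-fold lower number from compound 1 to compound 2 (0.04 log units; within the scatter), the expected step here is a 1.1-fold lower number from compound 3 to compound 4 (0.05 log units; within the scatter). Compound 4 is estimated at 19000 nM, with a likely range from 9000 nM to 40000 nM.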

Compound 4, half-maximal inhibitory concentration: 19000 nM
Compound 4: middle estimate and measured number agree at the digits printed; the range from low to high includes it.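

The new step, read in this assay, is a 1.1-fold lower number from compound 3 to compound 4 (0.05 log units; within the scatter), so on this second core the change from hydroxycarbamoyl to (hydroxycarbamoyl)methyl again leaves the number essentially where it was. Set side by side, the two steps agree: the same change on two cores in this assay, a 1.1-fold lower number (0.04 log units; within the scatter) from compound 1 to compound 2 and a 1.1-fold lower number (0.05 log units; within the scatter) from compound 3 to compound 4, 1.0-fold (0.01 log units) apart, within the scatter of two such steps

So within these four compounds, the change behaves alike on both cores, whether it sits eight bonds or four bonds along the chain from an aromatic nitrogen. This does not show that the change improves or weakens inhibition, since neither step can be told apart from the scatter, and two pairs that barely move are a weak test: they do not show that a step of real size would carry over from one core to the other, or that other cores would behave the same way.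

On these data alone, the two cores appear here only with different chains, so what the core alone contributes at a matched chain remains open. Also open, as far as these compounds go, is how the number would respond to a much shorter or much longer chain on either core, or to a carboxylic acid or a primary amide in place of the hydroxycarbamoyl group at the chain end.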